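Nitro Replaces Fluoro: Expectation for Compound 3

This account rests on a few compounds, and the source may have more. Where it says the series, first, only, none or still open, it means among the compounds named here.

Compound 1 `O=C1C2CCCN2C(=O)N1CN1CCN(c2ccccc2)CC1`: 1000 nM in an assay on isolated protein for binding affinity to Adrenergic receptor alpha-1 (Rattus norvegicus), read by radioligand binding; a higher number here means a weaker inhibitor, a lower number a stronger inhibitor
Compound 2 `O=C1C2CCCN2C(=O)N1CN1CCN(c2ccc(F)cc2)CC1`: > 1000 nM in this assay

In this assay compound 1 gives 1000 nM. For compound 2 the assay reports only a limit, > 1000 nM, so compound 2 stands at the weak edge of what was measured. For the measured compounds named here, the single measured step, a number no lower from compound 1 to compound 2 (the limit leaves the size open), points no lower, and its size stays open because compound 2 sits at the limit of > 1000 nM in this assay, at which 1 of the 2 values shown sits.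

Compound 3 `O=C1C2CCCN2C(=O)N1CN1CCN(c2ccc([N+](=O)[O-])cc2)CC1` differs from compound 2 by nitro in place of fluoro on an aromatic carbon. Going by the values given here, only that one step bears on this change, and it gives no sign of a gain. Compound 3 is therefore expected near 2000 nM, within 700 nM to 6000 nM. This estimate means an expected step that the limit leaves unreadable from compound 2 to compound 3, with a real chance that only a limit is reported again.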

Compound 3, inhibition constant: > 10000 nM
Compound 3 ended at the assay's limit (the forecaster's own chance of this, stated with the estimate: 60%); at least 5.0-fold (0.69 log units) between middle value and limit.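

In this assay, nitro in place of hydrogen on the aromatic carbon para to a large group gives an at least 10-fold higher number from compound 1 to compound 3 (1.00 log units; beyond the scatter). For the compounds shown here, this is the first change at this position with a size that clears the scatter, and it goes toward weaker binding. For compound 3, > 10000 nM is a limit of the assay, and the steps involving compound 2 cannot be read.

As far as these compounds go, how fluoro and nitro rank against each other stays open. So does whether an amine or a methoxy group here would give a lower number than compound 1.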